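The source may report more compounds than this note shows. Statements on the series, on what has been measured and on what is new or still open speak of the compounds shown alone.

Measured in an assay on isolated protein for displacement of a labelled ligand from Motilin receptor (Homo sapiens); on this read-out lower numbers stand for stronger inhibition and higher numbers for weaker inhibition:
compound 1, `CCC[C@@H]1NC(=O)[C@@H](C(C)C)NC(=O)[C@@H](Cc2ccc(O)cc2)NCCOc2ccccc2CCCNC1=O`, gives 55 nM.
compound 2, `CCC[C@@H]1NC(=O)[C@@H](C(C)C)NC(=O)[C@@H](CC2CCCCC2)NCCOc2ccccc2CCCNC1=O`, gives 3250 nM.
compound 3, `CCC[C@@H]1NC(=O)[C@@H](C(C)C)NC(=O)[C@@H](c2ccccc2)NCCOc2ccccc2CCCNC1=O`, reaches only the limit of this assay, > 10000 nM.

Compound 1 stands at the lowest of the two numbers in this assay. The nearest number is that of compound 2, and the step of a 59-fold higher number from compound 1 to compound 2 (1.77 log units; beyond the scatter) is beyond the scatter. The step of an at least 180-fold higher number from compound 1 to compound 3 (2.25 log units; beyond the scatter) runs to a limit, as does an at least 3.0-fold higher number from compound 2 to compound 3 (0.48 log units; beyond the scatter); the limit is the limit of > 10000 nM in this assay, at which 1 of the 3 values shown sits.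

Compound 4, `CCC[C@@H]1NC(=O)[C@@H](C(C)C)NC(=O)[C@@H](Cc2ccc(O)cc2)N(C(C)=O)CCOc2ccccc2CCCNC1=O`, differs from compound 1 in one place: acetyl in place of hydrogen on an amine nitrogen in a ring. Among the measured compounds shown here, none of the measured steps touches this amine nitrogen. The three steps that are known all swap the group on the ring carbon that bears the 4-hydroxybenzyl group, and each of them made the number larger, in two cases out to the limit. For the acetyl on the ring nitrogen there is therefore no direct comparison, and the size of the step in this assay can only be guessed. Given that every change to the shared core so far has weakened binding, the account expects a larger number for compound 4 as well, with wide uncertainty: the estimate for compound 4 is 1000 nM, between 150 nM and 8000 nM, which corresponds to the expected step of an 18-fold higher number from compound 1 to compound 4 (1.26 log units; beyond the scatter).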

Compound 4, inhibition constant: 6390 nM
The estimate for compound 4 lay 6.4-fold (0.81 log units) below the measured number; low and high end bracket the measured number.
By their numbers in this assay, from the lowest: compound 1; then compounds 2 and 4 (each within the scatter of the next). At a limit, above all of these: compound 3.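

Compound 4 shows that the amine nitrogen in the ring matters for this read-out as well: in this assay, acetyl in place of hydrogen gives a 120-fold higher number from compound 1 to compound 4 (2.07 log units; beyond the scatter), a large step. The earlier steps shown here all changed the group on the ring carbon, whereas here the 4-hydroxybenzyl group stays in place and the change on the amine nitrogen next to the ring atom that bears it is enough, on its own, to weaken binding by a large step. Nothing shown here gives a cause for this step.

Going by these compounds, what stays open is whether the loss comes from removing the hydrogen on this nitrogen or from the acetyl that enters, and a methyl, an ethyl or a longer chain on the same nitrogen would help to separate the two. On these data alone, it is also open how an acetyl on this nitrogen would read with a cyclohexylmethyl group on the ring carbon, or whether an amine or a carboxylic acid carried on the nitrogen substituent would recover any of the binding.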